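A hydroxyphenyl swap in a series with close values

The source may hold more compounds than are shown below. What is called first, only, known or untested is meant among the compounds shown, and "the series" means these compounds.

compound 1 `Cc1ccc(/C=C/C(=O)c2ccccc2NC(=O)NS(=O)(=O)c2ccc(C)cc2)cc1`: 15.3 ug/mL
compound 2 `COc1ccc(/C=C/C(=O)c2ccccc2NC(=O)NS(=O)(=O)c2ccc(C)cc2)cc1OC`: 12.9 ug/mL
compound 3 `CCc1cc(/C=C/C(=O)c2ccccc2NC(=O)NS(=O)(=O)c2ccc(C)cc2)cc(OC)c1OC`: 19.2 ug/mL

These values come from an ADME assay on the whole organism for cytotoxicity, with Artemia salina as the target, with a stated time of 24 h; a lower number here means that less compound is needed, a higher number that more compound is needed for the effect. Compound 2 at 12.9 ug/mL has the lowest number of the three, but it lies within the usual scatter of both other compounds, so the three cannot truly be ranked.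

The unmeasured compound 4 `Cc1ccc(S(=O)(=O)NC(=O)Nc2ccccc2C(=O)/C=C/c2cccc(O)c2)cc1` keeps the shared core and differs from compound 2 in one group. On a double-bonded chain carbon bound to a double-bonded chain carbon, 3-hydroxyphenyl stands in place of 3,4-dimethoxyphenyl (3-hydroxyphenyl in place of 3,4-dimethoxyphenyl on a double-bonded chain carbon bound to a double-bonded chain carbon).

Among the measured compounds shown here, three measured steps bear on this change. Replacing the whole group gave a 1.2-fold lower number from compound 1 to compound 2 (0.07 log units; within the scatter) and also a 1.3-fold higher number from compound 1 to compound 3 (0.10 log units; within the scatter), while adding an ethyl group to that same ring gave a 1.5-fold higher number from compound 2 to compound 3 (0.17 log units; within the scatter). All three stay within the scatter. For the measured compounds named here, no measured compound carries a hydroxy group, however, so the comparison is indirect and the range must stay wide.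

On this evidence, no step beyond the scatter is expected in this assay. The expected step is a 1.2-fold higher number from compound 2 to compound 4 (0.07 log units; within the scatter). For compound 4 the estimated value is 15 ug/mL, with an expected range from 7 ug/mL to 32 ug/mL.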

Compound 4, concentration for half-maximal effect: 39.3 ug/mL
For compound 4 the middle estimate is 2.6-fold (0.42 log units) below the measured one, outside the stated range (above it).
By their numbers in this assay, from the lowest: compounds 2, 1 and 3 (each within the scatter of the next); then compound 4.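

In this assay, the group on a double-bonded chain carbon bound to a double-bonded chain carbon can shift the number beyond the scatter after all: 3-hydroxyphenyl gives a 3.0-fold higher number from compound 2 to compound 4 (0.48 log units; beyond the scatter), a 2.6-fold higher number from compound 1 to compound 4 (0.41 log units; beyond the scatter) and a 2.0-fold higher number from compound 3 to compound 4 (0.31 log units; beyond the scatter), whereas the three earlier groups stayed within the scatter of one another. Set against 3,4-dimethoxyphenyl, 3-hydroxyphenyl has fewer heavy atoms and brings a hydrogen-bond donor, and since these differences arrive together in a single swap, the step cannot be assigned to either one alone. Nothing measured here accounts for the step, so its cause remains unknown.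

The compounds shown leave open whether the step belongs to the hydroxy group itself or to the loss of the methoxy groups, a question that 3-methoxyphenyl or plain phenyl at this place could help to settle. They also leave open whether a different group in the same spot, such as 3-aminophenyl, would move the number as far.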